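A Third Methoxy Group on the Shared Core

The compounds below may be only part of what the source reports. "The series", "measured", "known", "first", "only" and "open" are said of these compounds alone.

Compound 1 `COc1ccccc1/C=C1\CCC/C(=C\c2cccc(OC)c2OC)C1=O` opens the series. In a functional assay on A549 cells (Homo sapiens) for cytotoxicity, read by MTT assay, with a stated time of 72 h (a higher number here means a weaker inhibitor, a lower number a stronger inhibitor), compound 1 gives > 20000 nM, which is a limit of the assay and not a number. Compound 2 `COc1ccc(/C=C2\CCC/C(=C\c3cccc(OC)c3OC)C2=O)c(OC)c1` differs from it by methoxy in place of hydrogen on an aromatic carbon. In this assay compound 2 gives > 20000 nM, again a limit. The step that the two limits leave unreadable from compound 1 to compound 2 stays unreadable because of the limit of > 20000 nM in this assay, at which 2 of the 3 values shown sit. For the measured compounds named here, compound 3 `COc1cc(/C=C2\CCC/C(=C\c3ccc(OC)c(OC)c3)C2=O)cc(OC)c1` is the only one to yield a number: in this assay compound 3 gives 5100 nM. The difference between the cores of compound 1 and compound 3 is not broken down here. Compound 4 `COc1ccc(/C=C2\CCC/C(=C\c3cc(OC)c(OC)c(OC)c3)C2=O)cc1OC` differs from compound 3 by methoxy in place of hydrogen on an aromatic carbon, the same kind of change as from compound 1 to compound 2, though here the new group is ortho to two methoxy groups, there meta to a methoxy group. With the earlier step unreadable, the step of a 1.3-fold lower number from compound 3 to compound 4 (0.11 log units; within the scatter) is expected to be small, resting on compound 3 and its 5100 nM alone. Compound 4 is estimated at 4000 nM in this assay, between 1500 nM and 15000 nM.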

Compound 4, half-maximal inhibitory concentration: 2900 nM
For compound 4 the middle estimate is 1.4-fold (0.14 log units) above the measured one; low and high end bracket the measured number.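

In this assay, methoxy in place of hydrogen on an aromatic carbon, ortho to two methoxy groups, gives a 1.8-fold lower number from compound 3 to compound 4 (0.25 log units; within the scatter), so on this core the change does not move the result beyond the scatter. The same kind of change on the core of compound 1 cannot be read, since compound 1 and compound 2 both give a limit of the assay and not a number: the limit of > 20000 nM in this assay, at which 2 of the 4 values shown sit. The series therefore rests on a single readable step and does not show whether the change carries from one core to the other.

The compounds shown bear only methoxy groups on their aromatic rings, which leaves open what a hydroxy group, a fluorine atom or an amine would do in the same place. On these data alone, how these compounds behave in cells other than A549 also stays open.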